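From a Sulfur-Linked Group to Trifluoromethyl on the Carbonyl

A few compounds are considered here, and "the series" means these few. Any claim that something is new, unique, unknown or untested is made for them only; others in the source may bear on it.

Of the compounds shown here, three sharing one core have been tested in a functional assay on isolated protein for inhibition of Glucose-dependent insulinotropic receptor (Rattus norvegicus), read by HTRF and cAMP accumulation; on this read-out lower numbers stand for smaller maximal responses and higher numbers for larger maximal responses. Compound 1 `Cc1nc(S(C)(=O)=O)ccc1Oc1ncnc(OC2CCN(C(=O)OC(C)(C)CF)CC2)c1F` gives 95%. Compound 2 `CCC1(OC(=O)N2CCC(Oc3ncnc(Oc4ccc(S(C)(=O)=O)nc4C)c3F)CC2)CC1` gives 83%, and compound 3 `Cc1nc(S(C)(=O)=O)ccc1Oc1ncnc(OC2CCN(C(=O)SC(C)(C)C)CC2)c1F` gives 76%, the lowest of the three numbers, though its distance to compound 2 stays within the usual scatter, while its distance to compound 1 lies beyond it.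

Compound 4 `Cc1nc(S(C)(=O)=O)ccc1Oc1ncnc(OC2CCN(C(=O)C(F)(F)F)CC2)c1F` has not yet been measured. It differs from compound 3 in one place: trifluoromethyl in place of (tert-butyl)sulfanyl on a carbonyl carbon.

The measured steps that touch the same place are a number 19 percentage points lower from compound 1 to compound 3 (beyond the scatter) and a number 7 percentage points lower from compound 2 to compound 3 (within the scatter). Both alter the group on the carbonyl carbon, and both end at compound 3 with a modest drop or a change within the scatter. Going by the values given here, nothing measured so far carries a trifluoromethyl group at this position, so the direction of the new step is uncertain; the earlier steps suggest that changes here shift the maximal response only modestly.

For compound 4 a maximal response of 74% is expected, within a range from 55% to 92%. This estimate means a step of a number 2 percentage points lower from compound 3 to compound 4 (within the scatter), which is expected to stay within the scatter.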

Compound 4, largest response reached (reported as efficacy), in percent of the reference or control that the assay uses: 76%
The estimate for compound 4 lay 2 percentage points below the measured number, and the stated range covers the measured number.
By their numbers in this assay, from the lowest: compounds 3, 4 and 2 (each within the scatter of the next); then compound 1.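

In this assay, replacing the group on the carbonyl carbon gives no change at the digits printed from compound 3 to compound 4 (within the scatter), so removing the sulfur link and the tert-butyl group together, with trifluoromethyl in their place, leaves the maximal response unmoved at this resolution. This new group also gives a number 7 percentage points lower from compound 2 to compound 4 (within the scatter) and a number 19 percentage points lower from compound 1 to compound 4 (beyond the scatter), which puts compound 4 level with compound 3 in how it relates to both earlier compounds and leaves compound 1 as the only one separated from the rest beyond the scatter. No measurement offered here bears on this result.

The compounds shown leave open how widely this position accepts change, for example whether an amine, a carboxylic acid or a longer chain on the carbonyl carbon would keep the maximal response in the same range. They also leave open whether the higher number of compound 1 belongs to its 1-(fluoromethyl)-1-methylethyl group as a whole or to a single part of that group.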